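The source may report more compounds than this note shows. Statements on the series, on what has been measured and on what is new or still open speak of the compounds shown alone.

Compound 1 `CCCC[C@H]1CC[C@H](c2ccc(NC(=S)Nc3cccc(C(F)(F)F)c3)cc2)CC1`: 22000 nM
Compound 2 `COc1cccc(NC(=S)Nc2cccc(C(F)(F)F)c2)c1`: 26000 nM

Within the data shown here, in an ADME assay on MT4 cells (Homo sapiens) for cytotoxicity (on this read-out higher numbers stand for lower toxicity in this test and lower numbers for higher toxicity in this test), compound 2 at 26000 nM lies within the scatter of compound 1 at 22000 nM, the only other compound measured, so neither stands apart. Compound 3 `FC(F)(F)c1cccc(NC(=S)Nc2ccccc2)c1` has hydrogen in place of methoxy on an aromatic carbon. Among the measured compounds shown here, no measured step shows what this change does, but the two values stay close although the two structures differ widely. No shift beyond the scatter is therefore expected in this assay, in either direction. The estimated step of a 1.1-fold higher number from compound 2 to compound 3 (0.03 log units; within the scatter) stays small. For compound 3 the expected value is 28000 nM, with an estimated range of 13000 nM to 60000 nM.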

Compound 3, half-maximal cytotoxic concentration: 39000 nM
Estimate against measurement, compound 3: 1.4-fold (0.14 log units) below; the measured number falls inside the stated range.
By their numbers in this assay, from the lowest: compounds 1, 2 and 3 (each within the scatter of the next).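

In this assay hydrogen in place of methoxy on the aromatic carbon gives a 1.5-fold higher number from compound 2 to compound 3 (0.18 log units; within the scatter) and so leaves the read-out within the scatter, now shown by a direct step at this position. Hydrogen in place of 4-butylcyclohexyl gives a 1.8-fold higher number from compound 1 to compound 3 (0.25 log units; within the scatter) and also stays within the scatter, so neither group stands apart from hydrogen here. No available evidence bears on why these values stay together. Going by these compounds, whether an amine or a carboxylic acid at this position would bring a shift beyond the scatter remains open.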